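The source may hold more compounds than are shown below. What is called first, only, known or untested is meant among the compounds shown, and "the series" means these compounds.

Measured compounds:
Compound 1, `Cc1nn(-c2ncnc3nc[nH]c23)c2c1C(C(=O)Nc1ccccc1)CC(=O)N2`, in a functional assay on HEK293 cells for agonist activity at G-protein coupled receptor 39 (Homo sapiens), read by scintillation proximity assay and inositol phosphate accumulation, with a stated time of 75 min, in the presence of a further agent that is not named here; on this read-out higher numbers stand for an effect only at larger amounts of compound and lower numbers for an effect already at smaller amounts: compound 1 gives 10 nM.
Compound 2, `Cc1nn(-c2ncnc3nc[nH]c23)c2c1C(OCc1ccccc1F)CC(=O)N2`, in this assay: compound 2 gives 4 nM.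
Compound 3, `CCCCCCCCOC1CC(=O)Nc2c1c(C)nn2-c1ncnc2nc[nH]c12`, in this assay: compound 3 gives 8 nM.

Compound 3 sits in the middle of these three numbers, and neither gap is beyond the scatter: there is a 1.3-fold lower number from compound 1 to compound 3 (0.10 log units; within the scatter) and a 2.0-fold higher number from compound 2 to compound 3 (0.30 log units; within the scatter). For the measured compounds named here, only the step of a 2.5-fold lower number from compound 1 to compound 2 (0.40 log units; beyond the scatter) is a modest shift beyond the scatter.

Compound 4, `Cc1nn(-c2ncnc3nc[nH]c23)c2c1C(C(=O)NCc1ccccc1)CC(=O)N2`, has not yet been measured. It differs from compound 3 in one place: benzylcarbamoyl in place of octyloxy on a saturated ring carbon. The step that bears most directly on this is a 1.3-fold lower number from compound 1 to compound 3 (0.10 log units; within the scatter), where the octyloxy group took the place of a phenylcarbamoyl group at the same ring carbon without a shift beyond the scatter. Compound 4 reverses that exchange with a closely related carbamoyl group, benzylcarbamoyl, so the expectation is an equally small step. The step of a 2.0-fold higher number from compound 2 to compound 3 (0.30 log units; within the scatter) shows that the ether chain and the fluorinated benzyl ether also sit within the scatter of each other, which again gives no reason to expect a large move.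

Compound 4 is therefore expected to show a 1.1-fold higher number from compound 3 to compound 4 (0.05 log units; within the scatter), essentially none beyond the scatter. The estimate for compound 4 is 9 nM, with a range from 3 nM to 30 nM.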

Compound 4, half-maximal effective concentration: 5 nM
Beside the measured number, compound 4's estimate is 1.8-fold (0.26 log units) above it; the range from low to high includes it.
By their numbers in this assay, from the lowest: compounds 2, 4, 3 and 1 (each within the scatter of the next, the first and the last beyond it).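

In this assay, the benzylcarbamoyl group of compound 4 stays within the scatter of both ether groups at this saturated ring carbon (a 1.6-fold lower number from compound 3 to compound 4 (0.20 log units; within the scatter); a 1.3-fold higher number from compound 2 to compound 4 (0.10 log units; within the scatter)). The earlier compounds shown here had compared the ethers only with a phenylcarbamoyl group. Compound 4 shows that a carbamoyl group carrying a benzyl group can also sit here, and that this carbamoyl group, unlike the phenylcarbamoyl group, is not separated from the (2-fluorobenzyl)oxy group by more than the scatter. For the compounds shown here, the exchange within the carbamoyl group itself, benzyl in place of phenyl on the amide-type nitrogen, also stays within the scatter (a 2.0-fold lower number from compound 1 to compound 4 (0.30 log units; within the scatter)), so the only step beyond it remains the modest one between the phenylcarbamoyl and (2-fluorobenzyl)oxy groups (a 2.5-fold lower number from compound 1 to compound 2 (0.40 log units; beyond the scatter)). Nothing measured here explains why these different groups give such similar numbers.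

The compounds shown leave open whether a hydroxyl, an amine or a carboxylic acid on this ring carbon would keep the number in the same range. They also leave open whether it would hold with a methyl group in place of the amide hydrogen.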